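Cytotoxicity notes: from compound 3 to compound 4

This account rests on a few compounds, and the source may have more. Where it says the series, first, only, none or still open, it means among the compounds named here.

Of the compounds shown here, three have been read in an ADME assay on HEK-293T cells (Homo sapiens) for cytotoxicity, read by luminescence, with a stated time of 24 h; on this read-out lower numbers stand for higher toxicity in this test and higher numbers for lower toxicity in this test. Compound 1 `COc1ccc(Cn2c(C(=O)N3CCC(C(=O)NCCC(C)C)CC3)cc3sccc32)cc1` gives 30900 nM and compound 3 `CCCNC(=O)C1CCN(C(=O)c2c(Br)c3sccc3n2Cc2ccc(OC)cc2)CC1` gives 31600 nM, two values within the scatter of each other. Compound 2 `CCCNC(=O)C1CCN(C(=O)c2cc3sc(Br)cc3n2Cc2ccc(OC)cc2)CC1` reads > 100000 nM, which is a limit of the assay and not a number. Compound 4 `CCCNC(=O)C1CCN(C(=O)c2c(CNC(C)c3ccccc3)c3sccc3n2Cc2ccc(OC)cc2)CC1` carries ((1-phenylethyl)amino)methyl in place of bromo on an aromatic carbon of compound 3 (((1-phenylethyl)amino)methyl in place of bromo on an aromatic carbon). Among the compounds with values here, no measured step covers this change, so the expectation is loose: a moderate move toward lower numbers in this assay, meaning higher toxicity. The expected step is a 2.3-fold lower number from compound 3 to compound 4 (0.35 log units; beyond the scatter). For compound 4 the estimated value is 14000 nM, with an expected range of 4000 nM to 45000 nM.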

Compound 4, half-maximal cytotoxic concentration: 57500 nM
Compound 4: middle estimate off by 4.1-fold (0.61 log units), on the low side; the measured number lies above the stated range.
By their numbers in this assay, from the lowest: compounds 1, 3 and 4 (each within the scatter of the next). At a limit, above all of these: compound 2.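

At this aromatic carbon, bromo can be replaced by ((1-phenylethyl)amino)methyl, which brings 10 heavy atoms and a six-membered aromatic ring, and this assay shows a 1.8-fold higher number from compound 3 to compound 4 (0.26 log units; within the scatter). So this much larger substituent does not move the read-out beyond the scatter. Nothing shown gives a reason for the size of this step. Still open, going by these compounds, is how a simple aminomethyl group or a carboxylic acid at this carbon would read. Also open, on these data alone, is whether the phenyl ring or the amine nitrogen of the new group matters to the read-out.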